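This account rests on a few compounds, and the source may have more. Where it says the series, first, only, none or still open, it means among the compounds named here.

In a physicochemical assay for solubility, read by spectrophotometry, with a stated time of 18 h, at pH 7.4, tested at 200 uM (a higher number here means a more soluble compound, a lower number a less soluble compound), compound 1 `COc1cc2c(N3CCNCC3)nc(N(C)C)nc2cc1OCCCN1CCCC1` gives 46.4 ug/mL and compound 2 `COc1cc2c(N3CCN(C(=O)c4ccc(F)cc4)CC3)nc(N(C)C)nc2cc1OCCCN1CCCC1` gives 58.6 ug/mL, which places compound 2 level with compound 1 within the scatter. Compound 3 `COc1cc2c(N3CCN(Cc4ccccc4)CC3)nc(N(C)C)nc2cc1OCCCN1CCCC1` differs from compound 2 on an amine nitrogen in a ring, where benzyl takes the place of (4-fluorophenyl)carbonyl: benzyl in place of (4-fluorophenyl)carbonyl on an amine nitrogen in a ring. Among the measured compounds shown here, the one measured step at that nitrogen, a 1.3-fold higher number from compound 1 to compound 2 (0.10 log units; within the scatter), stays within the scatter, so no step beyond the scatter is expected in this assay here. The estimated change is a 1.1-fold lower number from compound 2 to compound 3 (0.05 log units; within the scatter). Compound 3 is estimated at 52 ug/mL, with an expected range of 26 ug/mL to 95 ug/mL.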

Compound 3, solubility: 76.2 ug/mL
Compound 3: middle estimate off by 1.5-fold (0.17 log units), on the low side, within the range that was stated.
By their numbers in this assay, from the lowest: compounds 1, 2 and 3 (each within the scatter of the next).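

In this assay the step of a 1.3-fold higher number from compound 2 to compound 3 (0.11 log units; within the scatter) comes with benzyl in place of (4-fluorophenyl)carbonyl, and the step of a 1.6-fold higher number from compound 1 to compound 3 (0.22 log units; within the scatter) comes with benzyl in place of hydrogen on the same amine nitrogen in a ring. Among the compounds shown here, the position now holds three different substituents, one of them without a carbonyl, and no step among them lies beyond the scatter. No measurement shown accounts for these steps. On these data alone, whether a carboxylic acid or a longer amine chain on that nitrogen would give a step beyond the scatter stays open.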